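A Single Stereocentre Flip on a Peracetylated Sugar

A few compounds are considered here, and "the series" means these few. Any claim that something is new, unique, unknown or untested is made for them only; others in the source may bear on it.

Compound 1 `CC(=O)O[C@@H]1[C@@H](OC(C)=O)[C@H](OC(C)=O)CO[C@H]1n1[se]c2ccccc2c1=O`: 6400 nM
Compound 2 `CC(=O)OC[C@H]1O[C@@H](n2[se]c3ccccc3c2=O)[C@H](OC(C)=O)[C@@H](OC(C)=O)[C@@H]1OC(C)=O`: 18000 nM

In a functional assay on HCT-116 cells (Homo sapiens) for cytotoxicity, read by resazurin assay, with a stated time of 48 h (a lower number here means a stronger inhibitor, a higher number a weaker inhibitor), compound 2 gives the higher of the two numbers. Among the compounds with values here, the only measured step is a 2.8-fold higher number from compound 1 to compound 2 (0.45 log units; beyond the scatter), a change in the groups present rather than in configuration. Compound 3 `CC(=O)OC[C@H]1O[C@@H](n2[se]c3ccccc3c2=O)[C@H](OC(C)=O)[C@@H](OC(C)=O)[C@H]1OC(C)=O` differs from compound 2 as follows: the two compounds have the same atoms and bonds and differ only in configuration as drawn: 1 of 5 stereo elements differ; a stereocentre at a saturated ring carbon is drawn R in compound 2 and S in compound 3. Within the data shown here, no measured step speaks to an inversion at one stereocentre, so there is no basis for expecting a change beyond the scatter in this assay. Compound 3 is therefore expected at 18000 nM, within 8000 nM to 40000 nM. That expectation amounts to no change at the digits printed from compound 2 to compound 3 (within the scatter).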

Compound 3, half-maximal inhibitory concentration: 17800 nM
Beside the measured number, compound 3's estimate is 1.0-fold (0.00 log units) above it; measured number inside the range.
By their numbers in this assay, from the lowest: compound 1; then compounds 3 and 2 (each within the scatter of the next).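

In this assay, inverting the stereocentre at this saturated ring carbon gives a 1.0-fold lower number from compound 2 to compound 3 (0.00 log units; within the scatter), so drawing it R or S makes no detectable difference here. The earlier step changed the groups present, whereas this one tests configuration alone, and the comparison is direct: the fact that compounds 2 and 3 differ only in the configuration as drawn

The compounds shown leave open whether inverting any of the other stereo elements would matter as little. They also leave open whether this one inversion would still make no difference with hydroxyl groups in place of the acetoxy groups.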